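A few compounds are considered here, and "the series" means these few. Any claim that something is new, unique, unknown or untested is made for them only; others in the source may bear on it.

In an ADME assay on MDCK cells (Canis lupus familiaris) for permeability, read by LC-MS, with a stated time of 90 min, tested at 2 uM (a higher number here means that the compound crosses the layer faster, a lower number that the compound crosses the layer more slowly), compound 1 `Cc1cc(C)c(CN2CCc3c(Cl)cc([C@H](CO)[C@H]4CCOC4)c(Cl)c3C2=O)c(=O)[nH]1` gives 2.9 10^-6 cm/s as a single entry, and compound 2 `Cc1cc(C)c(CN2CCc3c(Cl)cc(C(CO)C4CCOC4)c(Cl)c3C2=O)c(=O)[nH]1` gives 2.5 10^-6 cm/s; 2.7 10^-6 cm/s (2 entries) over repeated entries. Compound 3 `Cc1cc(C)c(CN2CCc3c(Cl)cc([C@@H](CO)[C@@H]4CCCO4)c(Cl)c3C2=O)c(=O)[nH]1` gives 4.3 10^-6 cm/s and stands within the scatter of compound 1, as the step (a 1.5-fold higher number from compound 1 to compound 3 (0.17 log units; within the scatter)) shows. Compound 4 `Cc1cc(C)c(CN2CCc3c(Cl)cc(-c4c(C)noc4C)c(Cl)c3C2=O)c(=O)[nH]1` differs from compound 3 by one change on an aromatic carbon ortho to a chloro group (a group of 7 heavy atoms (5 carbon, 1 nitrogen, 1 oxygen; one five-membered aromatic ring with 2 hetero atoms) in place of a group of 8 heavy atoms (6 carbon, 2 oxygen; one five-membered non-aromatic ring with 1 hetero atom), on an aromatic carbon). The measured step exchanged one five-membered non-aromatic ring for another, whereas 3,5-dimethyl-1,2-oxazol-4-yl brings a five-membered aromatic ring, and it is only a weak guide here. A modest rise is expected, with wide margins (a 2.3-fold higher number from compound 3 to compound 4 (0.37 log units; beyond the scatter)). For compound 4 the estimated value is 10 10^-6 cm/s (expected range 4 10^-6 cm/s to 22 10^-6 cm/s).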

Compound 4, apparent permeability: 15.7 10^-6 cm/s
The estimate for compound 4 lay 1.6-fold (0.20 log units) below the measured number; the measured number falls inside the stated range.
By their numbers in this assay, from the lowest: compounds 1 and 3 (each within the scatter of the next); then compound 4.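

Among these compounds, at this aromatic carbon, ortho to a chloro group, exchanging one non-aromatic ring group for another stayed within the scatter, whereas 3,5-dimethyl-1,2-oxazol-4-yl gives the first steps beyond it in this assay, with a 3.7-fold higher number from compound 3 to compound 4 (0.56 log units; beyond the scatter) and a 5.4-fold higher number from compound 1 to compound 4 (0.73 log units; beyond the scatter). So the number here does respond to the group at this carbon, but this change swaps the ring type, removes the hydrogen-bond donor and removes both defined stereocentres at once. Nothing available separates these differences or explains the rise. Still open, on these data alone, is whether a plain phenyl ring or a pyridine gives a similar number at this carbon, and what an amine there would give.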